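Trimming the Chain End on a Shared Core

This account rests on a few compounds, and the source may have more. Where it says the series, first, only, none or still open, it means among the compounds named here.

Among the measured compounds shown here, in an assay for inhibition of Indoleamine 2,3-dioxygenase 1 (Homo sapiens), read by fluorescence, with a stated time of 24 h (a higher number here means a weaker inhibitor, a lower number a stronger inhibitor), compound 2 `CS(=N)(=O)CC(=O)NCCSc1nonc1/C(=N/O)Nc1ccc(F)c(Br)c1` gives 14 nM, the lowest of the two numbers measured so far, while compound 1 `COc1nonc1/C(=N/O)Nc1ccc(F)c(Br)c1` gives 39 nM, a gap beyond the usual scatter. Compound 3 `CS(=O)(=O)NCCSc1nonc1/C(=N/O)Nc1ccc(F)c(Br)c1` keeps the shared core and the chain but alters its end: a group of 4 heavy atoms (1 carbon, 2 oxygen, 1 sulfur; no ring) in place of a group of 7 heavy atoms (3 carbon, 1 nitrogen, 2 oxygen, 1 sulfur; no ring), on an amine nitrogen. For the measured compounds named here, no measured pair shows a change of this kind, so there is nothing to calibrate the step against. Compound 3 is expected to stay close, with a step in this assay estimated as a 1.4-fold higher number from compound 2 to compound 3 (0.15 log units; within the scatter), not beyond the scatter. The estimate for compound 3 is 20 nM, ranging from 7 nM to 60 nM.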

Compound 3, half-maximal inhibitory concentration: 9.3 nM
Beside the measured number, compound 3's estimate is 2.2-fold (0.33 log units) above it, within the range that was stated.
By their numbers in this assay, from the lowest: compounds 3 and 2 (each within the scatter of the next); then compound 1.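

In this assay, putting methylsulfonyl in place of the larger group on the amine nitrogen gives a 1.5-fold lower number from compound 2 to compound 3 (0.18 log units; within the scatter). This chain end can be replaced by the smaller group without moving the number beyond the scatter. The full chain with this shorter end, on the aromatic carbon, still differs clearly from the group it replaces there, with a 4.2-fold lower number from compound 1 to compound 3 (0.62 log units; beyond the scatter) as the step. No measurement available here explains either step.

Still open, as far as these compounds go, is how a plain acetyl group, a carboxylic acid or a longer chain would behave on that amine nitrogen. From the compounds shown here alone, the bare amine, with no end group at all, is equally open.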